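The compounds below may be only part of what the source reports. "The series", "measured", "known", "first", "only" and "open" are said of these compounds alone.

Of the compounds shown here, two have been tested so far in a functional assay on MCF7 cells (Homo sapiens) for antiproliferative activity, read by MTT assay, with a stated time of 72 h; a higher number here means a weaker inhibitor, a lower number a stronger inhibitor. Compound 1, `Cc1ccc(-c2cn(C/C=C3\OC(=O)C(OCc4ccccc4)=C3OCc3ccccc3)nn2)cc1`, returns only a limit, > 100000 nM, and not a number. The result for compound 1 is the limit of > 100000 nM in this assay, at which 1 of the 2 values shown sits. Compound 2, `O=C1O[C@H]([C@@H](O)Cn2cc(-c3cccc(O)c3)nn2)C(OCc2ccccc2)=C1OCc1ccccc1`, gives 51800 nM in this assay, and this is the only number shown for the set.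

Compound 3, `O=C1O[C@H]([C@@H](O)Cn2cc(-c3cc(F)cc(F)c3)nn2)C(OCc2ccccc2)=C1OCc1ccccc1`, has not yet been measured. It differs from compound 2 in one place: 3,5-difluorophenyl in place of 3-hydroxyphenyl on an aromatic carbon. Among the compounds with values here, no measured pair of compounds differs in only one place, so nothing here shows how such a change moves the number in this assay. The step of a 1.2-fold higher number from compound 2 to compound 3 (0.06 log units; within the scatter) is therefore expected to be none beyond the scatter, with the direction left open. Compound 3 is estimated at 60000 nM, with a range from 20000 nM to 200000 nM, and a fair chance that only a limit is reported.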

Compound 3, half-maximal inhibitory concentration: 27700 nM
The estimate for compound 3 lay 2.2-fold (0.34 log units) above the measured number; the measured number falls inside the stated range.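

In this assay, within the data shown here, this is the first pair of compounds that differ in one place, on an aromatic carbon of the five-membered aromatic ring with 3 nitrogen: 3,5-difluorophenyl in place of 3-hydroxyphenyl gives a 1.9-fold lower number from compound 2 to compound 3 (0.27 log units; within the scatter). The group that leaves has 1 hydrogen-bond donor and 1 hydrogen-bond acceptor, and the group that enters has neither, yet in this one pair the number does not move beyond the scatter. Even without that donor, compound 3 still gives a measured number, 27700 nM, rather than a limit.

Among these compounds, only this one swap can be read at this position, so it remains open whether a group such as an amine or a carboxylic acid would move the number further. Compound 1 differs from the others in more than one place and gives only a limit, so it offers no readable step: the limit of > 100000 nM in this assay, at which 1 of the 3 values shown sits.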